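Compound 4 and the limit shared by the series

A few compounds are considered here, and "the series" means these few. Any claim that something is new, unique, unknown or untested is made for them only; others in the source may bear on it.

Measured so far in a functional assay on Huh-7 cells (Homo sapiens) for inhibition, read by MTT assay, with a stated time of 48 h; a lower number here means a stronger inhibitor, a higher number a weaker inhibitor:
- compound 1 `Cc1nnsc1CO/N=C/c1c(C)nn(C)c1Oc1ccccc1Cl` gives > 50000 nM as a limit
- compound 2 `Cc1nnsc1CO/N=C/c1c(C)nn(C)c1Oc1ccc(I)cc1` gives > 50000 nM as a limit
- compound 3 `Cc1ccc(Oc2c(/C=N/OCc3snnc3C)c(C)nn2C)cc1` gives > 50000 nM as a limit

Compound 3 gives > 50000 nM as a limit, so it has no number of its own in this assay. The other two compounds share that position, with the limit of > 50000 nM in this assay, at which 3 of the 3 values shown sit, as the whole picture so far.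

Compound 4 `Cc1nnsc1CO/N=C/c1c(C)nn(C)c1Oc1cc(F)cc(F)c1` carries 3,5-difluorophenyl in place of 4-methylphenyl on an oxygen on an aromatic ring, with 3,5-difluorophenyl in place of 4-methylphenyl on an oxygen on an aromatic ring as the counted difference. Within the data shown here, three measured steps bear on this change: a step that the two limits leave unreadable from compound 1 to compound 3 and a step that the two limits leave unreadable from compound 2 to compound 3 and also a step that the two limits leave unreadable from compound 1 to compound 2 among the same measured set. None of them has a readable size, so they give no measured direction or size for the new group.

With compound 3 at > 50000 nM as a limit, the likeliest outcome for compound 4 is expected to be a reported limit as well. The expected step is a number no higher from compound 3 to compound 4 (the limit leaves the size open) on this reading, with no size beyond the scatter foreseen. The estimated value for compound 4 is 50000 nM with an expected range from 12000 nM to 100000 nM at its two ends.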

Compound 4, half-maximal inhibitory concentration: > 50000 nM
Compound 4: only a limit was reported (the forecaster's own chance of this, stated with the estimate: 70%); the middle value sits exactly at the limit.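

In this assay compound 4 gives > 50000 nM, which is a limit and not a number. Among these compounds, no step among compound 1, compound 2, compound 3 and compound 4 can be read, with all four at a limit: the limit of > 50000 nM in this assay, at which 4 of the 4 values shown sit. Going by these compounds, whether any group on the oxygen gives a measurable value, and how large any change would be, stays open.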